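A few compounds are considered here, and "the series" means these few. Any claim that something is new, unique, unknown or untested is made for them only; others in the source may bear on it.

Working notes on the series.

Compound 1 `C[C@H]1CC(Cl)=C([Si](C)(C)C)[C@@H](C2CCCCC2)O1` gives 31000 nM in a functional assay on SW1573 cells (Homo sapiens) for antiproliferative activity; a lower number here means a stronger inhibitor of growth, a higher number a weaker inhibitor of growth. Of the three measured compounds it carries the lowest number, but neither of the other two stands beyond the scatter of it. Compound 2 `C[C@H]1CC(Cl)=C[C@@H](C2CCCCC2)O1` gives 43000 nM in this assay, and the step of a 1.4-fold higher number from compound 1 to compound 2 (0.14 log units; within the scatter) shows the removal of the group of 4 heavy atoms on the double-bonded ring carbon leaves the read-out essentially unchanged. Compound 3 `C[Si](C)(C)C1=C(Cl)C[C@H](C2CCCCC2)O[C@@H]1C1CCCCC1` gives 48000 nM in this assay; the step of a 1.5-fold higher number from compound 1 to compound 3 (0.19 log units; within the scatter) likewise stays within the scatter.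

Compound 4 `C[C@@H]1O[C@H](C2CCCCC2)C([Si](C)(C)C)=C(Cl)[C@H]1C` is not yet measured. Against compound 1 the change is methyl in place of hydrogen on a saturated ring carbon. Within the data shown here, no measured step places a methyl at this position; the two steps known, from compound 1 to compound 2 and from compound 1 to compound 3, alter other parts of the shared core and both sit within the scatter. On that basis nothing beyond the scatter is expected from the added methyl, in either direction. The expected step of no change at the digits printed from compound 1 to compound 4 (within the scatter) is therefore taken as flat. For compound 4 the estimate in this assay is 31000 nM, with an expected range from 12000 nM to 80000 nM.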

Compound 4, concentration for total growth inhibition: 41000 nM
Beside the measured number, compound 4's estimate is 1.3-fold (0.12 log units) below it, within the range that was stated.
By their numbers in this assay, from the lowest: compounds 1, 4, 2 and 3 (each within the scatter of the next).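

In this assay, among these compounds, the step of a 1.3-fold higher number from compound 1 to compound 4 (0.12 log units; within the scatter) is the only reading at this saturated ring carbon, next to the ring atom that bears a chloro group, and it shows that methyl in place of hydrogen here leaves the read-out essentially unchanged. Among the compounds shown here, this adds a third place to the two already read through a 1.4-fold higher number from compound 1 to compound 2 (0.14 log units; within the scatter) and a 1.5-fold higher number from compound 1 to compound 3 (0.19 log units; within the scatter), so that all three single changes from compound 1 stay within the scatter, and no compound among the four goes against this. No accompanying measurement offers an explanation for this flat step.

Whether a hydroxyl, an amine or a longer chain on this same ring carbon would also leave the read-out flat remains open, since methyl is the only group shown here. Also open is whether methyl at this carbon combined with hydrogen in place of the group of 4 heavy atoms would stay within the scatter of compound 1, and no compound shown yet has a step beyond the scatter that would mark a part of the shared core on which the read-out depends.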